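Ring-nitrogen substituent variation on the benzimidazole acid series

This account rests on a few compounds, and the source may have more. Where it says the series, first, only, none or still open, it means among the compounds named here.

Measured so far:
- compound 1 `CC(C)c1onc(-c2c(Cl)cccc2Cl)c1COc1ccc(-c2nc3ccc(C(=O)O)cc3n2CC(C)(C)C)cc1`: 13 nM
- compound 2 `CCCn1c(-c2ccc(OCc3c(-c4c(Cl)cccc4Cl)noc3C(C)C)cc2)nc2ccc(C(=O)O)cc21`: 9.3 nM
- compound 3 `CCCC(CCC)n1c(-c2ccc(OCc3c(-c4c(Cl)cccc4Cl)noc3C(C)C)cc2)nc2ccc(C(=O)O)cc21`: 1.8 nM

In an assay on Huh-7 cells for agonist activity at Bile acid receptor (Homo sapiens), read by a luciferase reporter (on this read-out higher numbers stand for an effect only at larger amounts of compound and lower numbers for an effect already at smaller amounts), compound 3 gives the lowest number of the three. The values of compound 1 and compound 2 lie within the scatter of each other. Against both, compound 3 stands apart: a 7.2-fold lower number from compound 1 to compound 3 (0.86 log units; beyond the scatter) and a 5.2-fold lower number from compound 2 to compound 3 (0.71 log units; beyond the scatter), each a modest step beyond the scatter, and both share the same direction, a branched seven-carbon chain on the ring nitrogen going with a lower number than a shorter or less branched one.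

Compound 4 `CC(C)Cn1c(-c2ccc(OCc3c(-c4c(Cl)cccc4Cl)noc3C(C)C)cc2)nc2ccc(C(=O)O)cc21` is the next entry: isobutyl in place of 1-propylbutyl on an aromatic nitrogen. The change runs opposite to the two steps above, taking the ring-nitrogen group back to a four-carbon chain comparable in size to the propyl of compound 2 and the neopentyl of compound 1. The two measured steps into compound 3 therefore bear on it directly, and a step of similar size in the reverse direction is expected in this assay, a higher number for compound 4 than for compound 3, landing near the values of compound 1 and compound 2. The estimated step is a 5.0-fold higher number from compound 3 to compound 4 (0.70 log units; beyond the scatter). For compound 4 the expected value in this assay is 9 nM, with a range from 4 nM to 25 nM.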

Compound 4, half-maximal effective concentration: 5.26 nM
For compound 4 the middle estimate is 1.7-fold (0.23 log units) above the measured one; low and high end bracket the measured number.
By their numbers in this assay, from the lowest: compound 3; then compounds 4, 2 and 1 (each within the scatter of the next, the first and the last beyond it).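

In this assay isobutyl in place of 1-propylbutyl keeps the separation seen for compound 3 from the shorter groups (a 2.9-fold higher number from compound 3 to compound 4 (0.47 log units; beyond the scatter)), so that separation now holds against three smaller groups on this nitrogen rather than two. Compound 4 does not stand apart from the propyl chain (a 1.8-fold lower number from compound 2 to compound 4 (0.25 log units; within the scatter), within the scatter), but it does stand apart from neopentyl (a 2.5-fold lower number from compound 1 to compound 4 (0.39 log units; beyond the scatter), beyond the scatter), even though compound 1 and compound 2 lie within the scatter of each other, so the loss of a single methyl from neopentyl is enough to give a step at this position. No measurement shown here accounts for any of these steps.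

Still open, on these data alone, is whether the lower number of compound 3 goes with the length of its chains or with the branch on the carbon bound to the ring nitrogen; a straight heptyl, a 1-ethylpropyl and a cyclohexyl on the same nitrogen would help separate these readings. It is also open how this position responds to a chain carrying an ether oxygen or an amine, since all groups shown here are pure carbon chains.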